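The compounds below may be only part of what the source reports. "The series", "measured", "known", "first", "only" and "open" are said of these compounds alone.

Compound 1 `CC1=CC[C@H]2[C@H](CC[C@]2(C)O)C(C)(C)[C@@H]1CC[C@H]1[C@]2(C)CC[C@H](OC(=O)c3ccccc3Cl)C(C)(C)O[C@H]2CC[C@@]1(C)O` gives 12100 nM in a functional assay on MCF7 cells (Homo sapiens) for antiproliferative activity, read by MTT assay, with a stated time of 72 h; a lower number here means a stronger inhibitor, a higher number a weaker inhibitor
Compound 2 `CC1=CC[C@H]2[C@H](CC[C@]2(C)O)C(C)(C)[C@@H]1CC[C@H]1[C@]2(C)CC[C@H](OC(=O)c3ccccc3[N+](=O)[O-])C(C)(C)O[C@H]2CC[C@@]1(C)O` gives 5200 nM in this assay

Compound 2 holds the lower of these two numbers. Compound 3 `CC1=CC[C@H]2[C@H](CC[C@]2(C)O)C(C)(C)[C@@H]1CC[C@H]1[C@]2(C)CC[C@H](OC(=O)c3ccco3)C(C)(C)O[C@H]2CC[C@@]1(C)O` has furan-2-yl in place of 2-nitrophenyl on a carbonyl carbon. For the measured compounds named here, only one measured step bears on this (a 2.3-fold lower number from compound 1 to compound 2 (0.37 log units; beyond the scatter)), a modest one beyond the scatter, with nitro in place of chloro on an aromatic carbon, and it does not test furan-2-yl. Going by the values given here, with compound 2 at 5200 nM the lower of only two values, a modest rise is expected in this assay with little certainty about direction. The expected change is small (a 1.5-fold higher number from compound 2 to compound 3 (0.19 log units; within the scatter)). Compound 3 is estimated at 8000 nM (range 3000 nM to 20000 nM).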

Compound 3, half-maximal inhibitory concentration: 25700 nM
The estimate for compound 3 lay 3.2-fold (0.51 log units) below the measured number; the measured number lies above the stated range.
By their numbers in this assay, from the lowest: compound 2; then compound 1; then compound 3.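

Putting furan-2-yl on this carbonyl carbon weakens activity in this assay against both aryl esters: a 4.9-fold higher number from compound 2 to compound 3 (0.69 log units; beyond the scatter), and a 2.1-fold higher number from compound 1 to compound 3 (0.33 log units; beyond the scatter). The position therefore responds to a change of the whole ring as well as to the swap of chloro for nitro, and compound 3 holds the highest number of the three. Nothing measured here accounts for this difference.

On these data alone, what an unsubstituted phenyl, a thiophene ring, an amine-bearing aryl group or a plain alkyl chain would give on this carbonyl carbon remains open.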